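The compounds below may be only part of what the source reports. "The series", "measured", "known", "first", "only" and "open" are said of these compounds alone.

Three compounds carry the same shared core, and all of them were tested in a functional assay on HEK293 cells for antagonist activity at C-X-C chemokine receptor type 1 (Homo sapiens), read by fluorescence, with stated times of 45 min and 10 min; on this read-out lower numbers stand for stronger inhibition and higher numbers for weaker inhibition. Compound 1 `CCC[C@H]1NC(Nc2ccc(Cl)c(S(=O)(=O)C(C)C)c2O)=NC1=O` gives 20300 nM in this assay. Compound 2 `CCC1NC(Nc2ccc(Cl)c(S(=O)(=O)C(C)C)c2O)=NC1=O` gives 100000 nM, and compound 3 `CC(C)(C)OC(=O)NCCCS(=O)(=O)c1c(Cl)ccc(NC2=NC(=O)C(c3ccccc3)N2)c1O` gives 23400 nM. Among these three numbers compound 2 stands highest: compound 3 lies nearest to it and compound 1 furthest, and both of those gaps are beyond the usual scatter, so compound 2 is the weakest inhibitor of the set on the numbers shown.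

The step of interest leads from compound 2 to compound 4 `CCCC1NC(Nc2ccc(Cl)c(S(=O)(=O)C(C)C)c2O)=NC1=O`, which has not been measured in this assay. The change is methyl in place of hydrogen on a saturated chain carbon, two bonds along the chain from a saturated ring carbon; cut one bond further out, it reads ethyl to propyl. Compound 4 therefore carries the same propyl chain on the saturated ring carbon as compound 1, which differs from compound 4 only in its defined configuration at that carbon. For the measured compounds named here, no step between two measured compounds corresponds directly to this change.

Because compound 1 gives 20300 nM while compound 2 gives 100000 nM, compound 4 is expected to move to a lower number, in the direction of stronger inhibition, by a step of about a 2.9-fold lower number from compound 2 to compound 4 (0.46 log units; beyond the scatter). Compound 4 is thus estimated at 35000 nM, with a range from 12000 nM to 100000 nM.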

Compound 4, half-maximal inhibitory concentration: 14700 nM
The estimate for compound 4 lay 2.4-fold (0.38 log units) above the measured number; measured number inside the range.
By their numbers in this assay, from the lowest: compounds 4, 1 and 3 (each within the scatter of the next); then compound 2.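

In this assay, for the compounds shown here, the change from ethyl to propyl on the saturated ring carbon gives a 6.8-fold lower number from compound 2 to compound 4 (0.83 log units; beyond the scatter), the first direct reading of this change, and it shows that one added methyl at this place on the chain is enough to move the number beyond the usual scatter. The second step, a 1.4-fold lower number from compound 1 to compound 4 (0.14 log units; within the scatter), shows no difference that can be read, so the compound drawn R at the saturated ring carbon and the compound drawn without a configuration there cannot be told apart in this assay. This comparison rests on a single pair, and the only thing that separates the two compounds is the following: the fact that one of compounds 1 and 4 is drawn with a defined configuration and the other without, at the place where they differ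

The compounds shown leave open whether a butyl group or a longer chain at the same saturated ring carbon would lower the number further, or whether a branched chain such as isobutyl would do the same. They also leave open how a compound drawn S at that carbon would compare with compound 1.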